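From methylsulfonyl to (cyclopropylmethyl)carbonyl on an amine nitrogen

This account rests on a few compounds, and the source may have more. Where it says the series, first, only, none or still open, it means among the compounds named here.

Measured so far in a physicochemical assay for lipophilicity, using the shake flask method, measured as octanol-water partition, at pH 7.4; a lower number here means a more polar compound, a higher number a more lipophilic compound
compound 1 `CC(=O)N[C@H]1[C@H]([C@@H](O)[C@H](O)CNC(=O)c2ccc(Cl)cc2)O[C@@](OCc2cccc(F)c2F)(C(=O)O)C[C@@H]1O` gives -0.27
compound 2 `O=C(CCl)N[C@H]1[C@H]([C@@H](O)[C@H](O)CNC(=O)c2ccc(Cl)cc2)O[C@@](OCc2cccc(F)c2F)(C(=O)O)C[C@@H]1O` gives 0.35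
compound 3 `CS(=O)(=O)N[C@H]1[C@H]([C@@H](O)[C@H](O)CNC(=O)c2ccc(Cl)cc2)O[C@@](OCc2cccc(F)c2F)(C(=O)O)C[C@@H]1O` gives -0.17

The data show a number 0.10 log units higher from compound 1 to compound 3 (within the scatter) and a number 0.52 log units lower from compound 2 to compound 3 (beyond the scatter) and so place compound 3 in the low pair of the set. Compound 4 `O=C(CC1CC1)N[C@H]1[C@H]([C@@H](O)[C@H](O)CNC(=O)c2ccc(Cl)cc2)O[C@@](OCc2cccc(F)c2F)(C(=O)O)C[C@@H]1O` has (cyclopropylmethyl)carbonyl in place of methylsulfonyl on an amine nitrogen and keeps the rest of the core. Like compounds 1 and 2, it carries a carbonyl there. The closest guide is a number 0.62 log units higher from compound 1 to compound 2 (beyond the scatter) and shows that a change on the chain of that carbonyl group can shift the number. The expected step is a number 0.72 log units higher from compound 3 to compound 4 (beyond the scatter) in this assay and would be a modest or somewhat larger rise. The estimate for compound 4 is 0.55 (range 0.1 to 1).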

Compound 4, distribution coefficient: 0.31
Beside the measured number, compound 4's estimate is 0.24 log units above it; the range from low to high includes it.
By their numbers in this assay, from the lowest: compounds 1 and 3 (each within the scatter of the next); then compounds 4 and 2 (each within the scatter of the next).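

In this assay, a number 0.48 log units higher from compound 3 to compound 4 (beyond the scatter), so replacing methylsulfonyl with (cyclopropylmethyl)carbonyl on the amine nitrogen gives a step beyond the scatter. On a saturated chain carbon bound to a carbonyl carbon, cyclopropyl in place of hydrogen gives a number 0.58 log units higher from compound 1 to compound 4 (beyond the scatter), while cyclopropyl in place of chloro gives only a number 0.04 log units lower from compound 2 to compound 4 (within the scatter), so these two groups cannot be told apart here. Nothing given explains these steps. Still open, on these data alone, is whether an amine or a longer chain on that carbon would stay with cyclopropyl and chloro.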